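The compounds below may be only part of what the source reports. "The series", "measured", "known", "first", "only" and "open" are said of these compounds alone.

Measured in a functional assay on MDA-MB-231 cells (Homo sapiens), read by microscopy and transwell migration, with a stated time of 24 h; a lower number here means a stronger inhibitor, a higher number a weaker inhibitor:
- Compound 1 `CN(C(=O)c1ccccc1)c1nc(-c2ccccc2Cl)cs1`: 41.6 nM
- Compound 2 `CN(C(=O)c1ccccc1)c1nc(-c2cccc(Br)c2)cs1`: 437 nM

In this assay, compound 2 stands as the weaker of the pair, with the higher number. Compound 3 `CN(C(=O)c1ccccc1)c1nc(-c2ccc(Br)cc2)cs1` follows from 4-bromophenyl in place of 3-bromophenyl on an aromatic carbon. Among the measured compounds shown here, only one measured step bears on this change: an 11-fold higher number from compound 1 to compound 2 (1.02 log units; beyond the scatter). That step is large, but it alters the halogen as well as its position, so it gives the size of a possible change and no direction. No clear shift is therefore expected, and the range stays wide. The estimated step is a 1.5-fold lower number from compound 2 to compound 3 (0.16 log units; within the scatter). For compound 3 the expected value is 300 nM, with an estimated range of 70 nM to 1300 nM.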

Compound 3, half-maximal inhibitory concentration: 317 nM
Estimate against measurement, compound 3: 1.1-fold (0.02 log units) below; the range from low to high includes it.
By their numbers in this assay, from the lowest: compound 1; then compounds 3 and 2 (each within the scatter of the next).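

In this assay, 4-bromophenyl in place of 3-bromophenyl gives a 1.4-fold lower number from compound 2 to compound 3 (0.14 log units; within the scatter), so the two bromophenyl compounds cannot be told apart and the place of the bromine shows no effect here. Compound 1 stands apart from both, with 4-bromophenyl in place of its 2-chlorophenyl giving a 7.6-fold higher number from compound 1 to compound 3 (0.88 log units; beyond the scatter), although halogen and position change together in this step. No evidence at hand explains these results. A 2-bromophenyl or 4-chlorophenyl compound would separate halogen from position. From the compounds shown here alone, whether an amine or a carboxylic acid on this phenyl ring would be tolerated also stays open.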